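Toxicity limits and a 3-chlorophenyl swap

A few compounds are considered here, and "the series" means these few. Any claim that something is new, unique, unknown or untested is made for them only; others in the source may bear on it.

Compound 1 `Cc1c(O)nc(SCc2ccc(C#N)cc2)nc1Cc1c(Cl)cccc1Cl` gives > 60000 nM as a limit
Compound 2 `CCOc1ccc(CSc2nc(O)c(C)c(Cc3c(Cl)cccc3Cl)n2)cc1` gives > 58000 nM as a limit

In a functional assay on MT4 cells (Homo sapiens) for cytotoxicity, read by MTT assay (on this read-out lower numbers stand for higher toxicity in this test and higher numbers for lower toxicity in this test), both values are limits and not numbers. Compound 2 has only its limit of > 58000 nM to show. Compound 3 `Cc1c(O)nc(SCc2cccc(Cl)c2)nc1Cc1c(Cl)cccc1Cl` has 3-chlorophenyl in place of 4-ethoxyphenyl on a saturated chain carbon bound to a sulfur. Among the compounds with values here, the one measured step that bears on this is a step that the two limits leave unreadable from compound 1 to compound 2 and offers no size to carry over, so no step beyond the scatter and no direction is expected in this assay for this change. The expected step is a step that the limit leaves unreadable from compound 2 to compound 3 on this reasoning. Compound 3 is estimated at 59000 nM within an expected range of 25000 nM to 120000 nM. Compound 3 is expected to give perhaps only a limit again.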

Compound 3, half-maximal cytotoxic concentration: > 59000 nM
Compound 3: only a limit was reported; the forecaster's own chance of this, stated with the estimate: 75%; the middle value sits exactly at the limit.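

Within the data shown here, compound 3 gives only a limit, > 59000 nM, in this assay, so no step from compound 1 or compound 2 to compound 3 can be read. The compounds shown leave open whether 4-ethoxyphenyl, 3-chlorophenyl or 4-cyanophenyl makes any difference to toxicity in this test.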